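From benzyloxy to cyclohexylmethoxy on the shared core

This account rests on a few compounds, and the source may have more. Where it says the series, first, only, none or still open, it means among the compounds named here.

compound 1 `COCCCCOc1ccc(C(O)C2OC(=O)c3c(OC)cc(OC)cc32)cc1` — 8210 nM
compound 2 `COc1cc(OC)c2c(c1)C(C(O)c1ccc(OCc3ccccc3)cc1)OC2=O` — > 10000 nM

In a functional assay on RAW264.7 cells (Mus musculus) for inhibition, read by Griess assay, with stated times of 1 h and 24 h (a lower number here means a stronger inhibitor, a higher number a weaker inhibitor), compound 1 gives 8210 nM. For compound 2 only a limit of the assay is known, > 10000 nM; it stands at the limit of > 10000 nM in this assay, at which 1 of the 2 values shown sits. Among the measured compounds shown here, the one measured step, an at least 1.2-fold higher number from compound 1 to compound 2 (0.08 log units; that floor lies within the scatter), has a floor that lies within the scatter, so it settles little about direction. Compound 3 `COc1cc(OC)c2c(c1)C(C(O)c1ccc(OCC3CCCCC3)cc1)OC2=O` differs from compound 2 by cyclohexyl in place of phenyl on a saturated chain carbon bound to an oxygen on an aromatic ring. For the measured compounds named here, no measured step covers a cyclohexyl entering for a phenyl on a saturated chain carbon bound to an oxygen on an aromatic ring, and compound 2 itself supplies only a limit, so the numbers give no size and no direction beyond the scatter for this change. Compound 3 is therefore expected to sit near that limit as well, with a wide range: 15000 nM (5000 nM to 50000 nM). The expected step is a step that the limit leaves unreadable from compound 2 to compound 3.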

Compound 3, half-maximal inhibitory concentration: > 10000 nM
Compound 3 ended at the assay's limit (the forecaster's own chance of this, stated with the estimate: 60%); the middle value lies beyond the limit too.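

In this assay, compound 3, with cyclohexyl in place of phenyl on a saturated chain carbon bound to an oxygen on an aromatic ring, gives > 10000 nM, which is a limit of the assay and not a number. Compound 2 alone could not show that a non-aromatic ring of the same size at this place also leaves the value at a limit. The step between these two limits cannot be read, and the other new step, an at least 1.2-fold higher number from compound 1 to compound 3 (0.08 log units; that floor lies within the scatter), settles no direction, so the two ring groups end alike at the limit: the limit of > 10000 nM in this assay, at which 2 of the 3 values shown sit.

From the compounds shown here alone, whether phenyl and cyclohexyl differ at all in this assay stays open, with only compound 1 giving a number. Also open, going by these compounds, is how an amine or a carboxylic acid at the end of this chain would read, or a chain longer than 3-methoxypropyl.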